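The source may report more compounds than this note shows. Statements on the series, on what has been measured and on what is new or still open speak of the compounds shown alone.

Measured compounds:
compound 1, `O=C(CCCCOc1ccccc1)OCC1COCCOCCOCCOCCOCCO1`, > 100000 nM
compound 2, `O=C(CCCCCc1ccccc1)OCC1COCCOCCOCCOCCOCCO1`, 78000 nM
compound 3, `O=C(OCC1COCCOCCOCCOCCOCCO1)c1cccc(-c2ccc(Br)cc2)c1`, 4400 nM

Three esters of one shared crown-ether alcohol were tested in a functional assay on SW1573 cells (Homo sapiens) for inhibition, read by sulforhodamine B assay, with a stated time of 48 h; on this read-out lower numbers stand for stronger inhibition of growth and higher numbers for weaker inhibition of growth. Compound 1 gives only a limit of the assay there, (the limit of > 100000 nM in this assay, at which 1 of the 3 values shown sits), and no number. Compound 2 gives the highest of the two numbers in this assay; its nearest neighbour, compound 3, sits at 4400 nM, a lower number and beyond the scatter. Within the data shown here, the one measured step, an at least 1.2-fold lower number from compound 1 to compound 2 (0.10 log units; that floor lies within the scatter), lies within the scatter.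

Compound 4, `CC/C=C/CC(=O)OCC1COCCOCCOCCOCCOCCO1`, has not been measured. It differs from compound 2 as follows: but-1-en-1-yl in place of 4-phenylbutyl on a saturated chain carbon bound to a carbonyl carbon. Among the measured compounds shown here, no measured step matches this change; the step from compound 1 to compound 2 only swaps one aromatic group for another at the chain end, so it says little here. For the measured compounds named here, compound 3, the only compound with a number beyond compound 2, carries a larger aromatic ester, while compound 4 drops the ring and shortens the chain; the account therefore expects compound 4 to move the other way, with a step of a 1.9-fold higher number from compound 2 to compound 4 (0.28 log units; within the scatter). Compound 4 is estimated at 150000 nM, within 50000 nM to 500000 nM, with a fair chance that only a limit is reported.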

Compound 4, concentration for 50% growth inhibition: > 100000 nM
Compound 4: only a limit was reported; the forecaster's own chance of this, stated with the estimate: 60%; the middle value does not contradict the limit.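

At the saturated chain carbon bound to a carbonyl carbon, but-1-en-1-yl in place of 4-phenylbutyl gives an at least 1.2-fold higher number from compound 2 to compound 4 (0.10 log units; that floor lies within the scatter) in this assay. The aromatic ring can therefore leave this place without any change that stands beyond the scatter, although the true size of the step stays hidden. Compound 4 gives only a limit and no number, and the step from compound 1 to compound 4 cannot be read, as both values are limits: the limit of > 100000 nM in this assay, at which 2 of the 4 values shown sit.

The compounds shown do not separate the loss of the ring from the shortening of the chain, as the two arrive together in one change. They also leave open how a longer chain without a ring, or an amine or a carboxylic acid at the chain end, would read out at this place.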